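The source may hold more compounds than are shown below. What is called first, only, known or untested is meant among the compounds shown, and "the series" means these compounds.

Compound 1 `CNc1nc2c(-c3ccnc(OC)c3)cnn2cc1OC`, in an ADME assay on microsomes from liver (Rattus norvegicus) for metabolic stability, with a stated time of 60 min, tested at 1 uM; on this read-out lower numbers stand for a less stable compound and higher numbers for a more stable compound: 74%
Compound 2 `COc1cc(-c2cnn3cc(OC)c([C@@H]4COC(C)(C)C4)nc23)ccn1`: 30%
Compound 3 `Cn1cc(-c2nc3c(-c4ccnc(OC5CC5)c4)cnn3cc2OCCCC(C)(C)O)cn1`: 64%

Compound 3, at 64%, lies within the usual scatter of compound 1 and well over compound 2 in this assay. Compound 4 `COc1cn2ncc(-c3ccnc(OC4CC4)c3)c2nc1-c1cnn(C)c1` has not been measured. It differs from compound 3 as follows: hydrogen in place of 3-hydroxy-3-methylbutyl on a saturated chain carbon bound to an oxygen on an aromatic ring. Hydrogen replaces 3-hydroxy-3-methylbutyl, which turns (4-hydroxy-4-methylpentyl)oxy into methoxy. For the measured compounds named here, no measured step covers this change. The only one, a number 44 percentage points lower from compound 1 to compound 2 (beyond the scatter), is large, but it concerns a different group on an aromatic carbon. Going by the values given here, it shows only that one change can matter greatly here, so the range must stay wide. No shift beyond the scatter is expected, and the estimated move is a number 2 percentage points higher from compound 3 to compound 4 (within the scatter). For compound 4 the estimate is 66%, with an expected range of 45% to 82%.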

Compound 4, percent of the compound remaining: 32%
For compound 4 the middle estimate is 34 percentage points above the measured one; the measured number lies below the stated range.
By their numbers in this assay, from the lowest: compounds 2 and 4 (each within the scatter of the next); then compounds 3 and 1 (each within the scatter of the next).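

Replacing (4-hydroxy-4-methylpentyl)oxy with methoxy is not a neutral change in this assay: the result is a number 32 percentage points lower from compound 3 to compound 4 (beyond the scatter). The earlier compounds shown here did not show that this place, on a saturated chain carbon bound to an oxygen on an aromatic ring, can strongly affect this read-out, and here the longer chain goes with the higher number. Nothing shown explains the difference.

Still open, going by these compounds, is whether the hydroxy group or the chain length matters more. A plain pentyl chain, or an ethyl group, would help separate the two.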